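From 4-fluorobenzyl to 3-bromobenzyl in the series

A few compounds are considered here, and "the series" means these few. Any claim that something is new, unique, unknown or untested is made for them only; others in the source may bear on it.

In a functional assay on SW 1116 cells (Homo sapiens) for antiproliferative activity, read by MTT assay, with a stated time of 24 h (a higher number here means a weaker inhibitor, a lower number a stronger inhibitor), compound 1 (`Clc1cccc(CSc2nnc(-c3ccc4c(c3)OCCO4)n2-c2ccccc2)c1`) gives 10600 nM and compound 2 (`Fc1ccc(CSc2nnc(-c3ccc4c(c3)OCCO4)n2-c2ccccc2)cc1`) gives 20800 nM. Compound 2 has only compound 1 to stand against, and these two values lie within the scatter of each other. Compound 3 (`Brc1cccc(CSc2nnc(-c3ccc4c(c3)OCCO4)n2-c2ccccc2)c1`) carries 3-bromophenyl in place of 4-fluorophenyl on a saturated chain carbon bound to a sulfur. Going by the values given here, the one measured step bearing on this change, a 2.0-fold higher number from compound 1 to compound 2 (0.29 log units; within the scatter), has 4-fluorophenyl entering where it leaves here, and that step stays within the scatter. It sets no firm direction, so no step beyond the scatter is expected in this assay. The estimated step, a 1.7-fold lower number from compound 2 to compound 3 (0.24 log units; within the scatter), is expected to stay within the scatter. Compound 3 is expected at 12000 nM, with an estimated range of 5000 nM to 28000 nM.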

Compound 3, half-maximal inhibitory concentration: 26200 nM
Beside the measured number, compound 3's estimate is 2.2-fold (0.34 log units) below it, within the range that was stated.
By their numbers in this assay, from the lowest: compounds 1, 2 and 3 (each within the scatter of the next, the first and the last beyond it).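

In this assay, going to 3-bromobenzyl from 4-fluorobenzyl gives a 1.3-fold higher number from compound 2 to compound 3 (0.10 log units; within the scatter) and so does not separate the two groups. The series now has its first step beyond the scatter: bromo in place of chloro on an aromatic carbon gives a 2.5-fold higher number from compound 1 to compound 3 (0.39 log units; beyond the scatter) as a modest move toward a weaker inhibitor, so this position registers even a single halogen exchange. Nothing available explains that step.

Going by these compounds alone, the only fluoro compound carries 4-fluorophenyl, so the identity of the halogen and its ring placement change together in the steps involving compound 2, and their contributions remain unseparated. Also open, as far as these compounds go, is how a phenyl ring bearing a methoxy group or a carboxylic acid, or a longer chain in place of the benzyl carbon, would read at this position.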